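A few compounds are considered here, and "the series" means these few. Any claim that something is new, unique, unknown or untested is made for them only; others in the source may bear on it.

Three measured compounds share one core and differ only in the group attached to the saturated chain carbon that bears the aromatic ring. Compound 1 `CC[C@H](C)[C@@H]1C(=O)N[C@H](C2Cc3ccccc3C2)C(=O)N1[C@@H](C(=O)N(C)C)c1ccc(C)[n+]([O-])c1` carries the ring with the oxygen on its nitrogen, compound 2 `CC[C@H](C)[C@@H]1C(=O)N[C@H](C2Cc3ccccc3C2)C(=O)N1[C@@H](C(=O)N(C)C)c1ccc(C)nc1C` carries a ring with two methyl groups, and compound 3 `CC[C@H](C)[C@@H]1C(=O)N[C@H](C2Cc3ccccc3C2)C(=O)N1[C@@H](C(=O)N1CCOCC1)c1ccc(C)nc1` carries the single-methyl ring together with a morpholine amide.

In an in vivo ADME assay on the whole organism for pharmacokinetics, with Rattus norvegicus as the target, at a dose of 5 mg/kg by the oral route (a higher number here means that a larger share of the oral dose reaches the circulation, a lower number that a smaller share of the oral dose reaches the circulation), compound 1 reaches only a limit of the assay, < 1% (the limit of < 1% in this assay, at which 1 of the 3 values shown sits). In this assay compound 2 gives 84%, and compound 3 gives 54%. Within the data shown here, the one measured step, a number at least 83 percentage points higher from compound 1 to compound 2 (beyond the scatter), shows how strongly the aromatic ring can move this read-out. Compound 3 stands lowest of the two numbers shown; its nearest neighbour is compound 2, which lies higher by an amount beyond the scatter.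

Compound 4 `CCC(CC)[C@@H]1C(=O)N[C@H](C2Cc3ccccc3C2)C(=O)N1[C@@H](C(=O)N1CCOCC1)c1ccc(C)nc1` keeps everything of compound 3 except one change: pentan-3-yl in place of sec-butyl on a saturated ring carbon. Among the measured compounds shown here, no measured step touches this saturated ring carbon, so nothing here tells how large a change to expect there, and the measured step from compound 1 to compound 2 concerns a different place. The step from compound 3 to compound 4 in this assay is therefore expected to be a number 4 percentage points lower from compound 3 to compound 4 (within the scatter), with no clear direction beyond the scatter. Compound 4 is expected to give 50%, within a range from 25% to 75%.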

Compound 4, oral bioavailability: 55%
Compound 4: middle estimate off by 5 percentage points, on the low side; measured number inside the range.
By their numbers in this assay, from the lowest: compounds 3 and 4 (each within the scatter of the next); then compound 2. At a limit, below all of these: compound 1.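

In this assay, putting pentan-3-yl in place of sec-butyl gives a number 1 percentage points higher from compound 3 to compound 4 (within the scatter). Among these compounds, this is the first measured change at this saturated ring carbon, and it shows that this read-out does not separate the two groups, even though pentan-3-yl adds one carbon and lacks the defined stereocentre of sec-butyl, whereas the earlier step concerned the aromatic ring and was large. No measurement shown here gives a reason for this result.

From the compounds shown here alone, only these two carbon groups appear at this position, so what a ring such as cyclohexyl, a longer chain or an amine would do there remains open. Going by these compounds, it is also open whether pentan-3-yl would leave the share of the oral dose reaching the circulation just as unmoved on compound 2, which has a dimethyl amide in place of the morpholine amide and a second methyl group on the aromatic ring.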